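Thiophene for Phenyl on a Nucleoside Core

The source may report more compounds than this note shows. Statements on the series, on what has been measured and on what is new or still open speak of the compounds shown alone.

Compound 1, `CSc1ncnc2c1c(-c1ccccc1)cn2[C@@H]1O[C@H](CO)[C@@H](O)[C@H]1O`: in a functional assay on A549 cells (Homo sapiens), read by MTT assay, with a stated time of 72 h (on this read-out lower numbers stand for stronger inhibition and higher numbers for weaker inhibition), compound 1 gives only a limit, > 20000 nM.
Compound 2, `CSc1ncnc2c1c(-c1ccsc1)cn2[C@@H]1O[C@H](CO)[C@@H](O)[C@H]1O`: in this assay compound 2 gives only a limit, > 20000 nM.
Compound 3, `Nc1nc2c(c(-c3ccccc3)cn2[C@@H]2O[C@H](CO)[C@@H](O)[C@H]2O)c(=O)[nH]1`: in this assay compound 3 gives only a limit, > 100000 nM.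

Compound 1 and compound 2 share one core and differ by thiophen-3-yl in place of phenyl on an aromatic carbon. The step that the two limits leave unreadable from compound 1 to compound 2 has no readable size: both compounds sit at the limit of > 20000 nM in this assay, at which 2 of the 3 values shown sit. Going by the values given here, compound 4, `Nc1nc2c(c(-c3ccsc3)cn2[C@@H]2O[C@H](CO)[C@@H](O)[C@H]2O)c(=O)[nH]1`, is the unmeasured partner of compound 3, and the change is thiophen-3-yl in place of phenyl on an aromatic carbon, at the same place, so it is the same change as the one from compound 1 to compound 2. How the core of compound 3 differs from the core of compound 1 is not broken down here. Compound 3 itself sits at the limit of > 100000 nM in this assay, at which 1 of the 3 values shown sits.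

The step that the limit leaves unreadable from compound 3 to compound 4 is therefore expected, resting on compound 3 at its limit > 100000 nM and on the unreadable step that the two limits leave unreadable from compound 1 to compound 2. Compound 4 is estimated at 150000 nM, most probably again reported only as a limit.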

Compound 4, half-maximal inhibitory concentration: > 20000 nM
Compound 4 ended at the assay's limit (the forecaster's own chance of this, stated with the estimate: 85%); the middle value does not contradict the limit.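

Going by these compounds alone, compound 3 and compound 4 each give only a limit of the assay, and no step between them can be read. The compounds shown leave open whether thiophen-3-yl in place of phenyl changes inhibition at all, on either core.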